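Solubility notes: acetylazetidinyl extension of compound 3

This account rests on a few compounds, and the source may have more. Where it says the series, first, only, none or still open, it means among the compounds named here.

In a physicochemical assay for solubility, read by spectrophotometry, measured as kinetic solubility, at pH 8, tested at 500 uM (on this read-out lower numbers stand for lower solubility and higher numbers for higher solubility), compound 3 `CNC(=O)c1ccncc1Nc1cc(-c2ccc3ccn(C)c3c2)c2nccnc2c1` gives 4 ug/mL. Compound 1 `CNS(=O)(=O)c1ccccc1Nc1cc(-c2ccc3ccn(C)c3c2)c2nccnc2c1` gives 2 ug/mL and compound 2 `Cn1cc(CNS(=O)(=O)c2ccccc2Nc2cc(-c3ccc4ccn(C)c4c3)c3nccnc3c2)cn1` gives 2 ug/mL in this assay; neither number is separated from that of compound 3 beyond the scatter, so the three compounds sit together on this read-out. Compound 4 `CC(=O)N1CC(CNC(=O)c2ccncc2Nc2cc(-c3ccc4ccn(C)c4c3)c3nccnc3c2)C1` differs from compound 3 by 1-acetylazetidin-3-yl in place of hydrogen on a saturated chain carbon bound to an amide-type nitrogen. For the measured compounds named here, the one measured step of comparable kind, a group entering on a saturated chain carbon bound to a sulfonamide nitrogen, is no change at the digits printed from compound 1 to compound 2 (within the scatter). On that basis no step beyond the scatter is expected for compound 4 in this assay, the expected step being a 1.3-fold higher number from compound 3 to compound 4 (0.10 log units; within the scatter). Compound 4 is therefore estimated at 5 ug/mL, with a range from 2 ug/mL to 15 ug/mL.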

Compound 4, solubility: 252 ug/mL
Beside the measured number, compound 4's estimate is 50-fold (1.70 log units) below it; the measured number lies above the stated range.
By their numbers in this assay, from the lowest: compounds 1, 2 and 3 (each within the scatter of the next); then compound 4.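

In this assay the place on a saturated chain carbon bound to an amide-type nitrogen carries a 63-fold higher number from compound 3 to compound 4 (1.80 log units; beyond the scatter) when 1-acetylazetidin-3-yl replaces hydrogen. For the compounds shown here, the one earlier step at a comparable place, on a carbon bound to a sulfonamide nitrogen, was no change at the digits printed from compound 1 to compound 2 (within the scatter) with a different group, so a substituent at such a place need not leave this read-out unmoved. Nothing shown accounts for the size of the step.

From the compounds shown here alone, whether the acetyl group or the four-membered ring goes with the step remains open. Also open, going by these compounds, is whether an amine, a carboxylic acid or a plain longer chain at this place gives a step of similar size.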